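The source may hold more compounds than are shown below. What is called first, only, known or untested is meant among the compounds shown, and "the series" means these compounds.

Of the compounds shown here, two have so far been measured in a physicochemical assay for solubility, read by HPLC, in phosphate buffer, measured as kinetic solubility, at pH 7.4; a lower number here means a less soluble compound, a higher number a more soluble compound. Compound 1 (`Cc1ccc(-c2ccc(Cl)cc2)n1-c1ccc(S(N)(=O)=O)cc1`) gives 6100 nM as the lower of the two numbers. Compound 2 (`CCC(=O)c1ccn(-c2ccc(S(N)(=O)=O)cc2)c1C`) gives 100000 nM and lies above compound 1 by a gap beyond the usual scatter of such measurements. Compound 1 therefore stands at the bottom of this very short scale. Compound 3 (`CCOC(=O)c1cc(-c2ccc(Cl)cc2)n(-c2ccc(S(N)(=O)=O)cc2)c1C`) differs from compound 1 in one place, with ethoxycarbonyl in place of hydrogen on an aromatic carbon as the counted change. The ethoxycarbonyl stands in place of hydrogen on an aromatic carbon, next to the ring atom that bears a methyl group. Within the data shown here, no measured pair isolates such a change, so what follows is a judgement and not a read-across. Compound 3 keeps the 4-chlorophenyl group of compound 1, which gives 6100 nM in this assay and is the lower of the two measured compounds, and a modest further drop is expected. The estimated size of this step is a 2.0-fold lower number from compound 1 to compound 3 (0.31 log units; beyond the scatter) and it may not clear the scatter by much. Compound 3 is expected at 3000 nM within an estimated range of 800 nM to 10000 nM in this measurement.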

Compound 3, solubility: 4200 nM
The estimate for compound 3 lay 1.4-fold (0.15 log units) below the measured number; the range from low to high includes it.
By their numbers in this assay, from the lowest: compounds 3 and 1 (each within the scatter of the next); then compound 2.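

In this assay, among these compounds, ethoxycarbonyl in place of hydrogen on an aromatic carbon gives a 1.5-fold lower number from compound 1 to compound 3 (0.16 log units; within the scatter) and so provides the first measured step at this position, which the earlier compounds could not supply. This read-out does not separate compound 1 from compound 3 and places them together at the low end of the three measured compounds, so the entering group, with its 5 heavy atoms and 2 hydrogen-bond acceptors, brings no change here that stands clear of repeat measurements. No available evidence accounts for this result.

The compounds shown leave open whether a carboxylic acid, a primary amide or an aminomethyl group on this same aromatic carbon, in place of ethoxycarbonyl, would move the number in this assay beyond the scatter, with the 4-chlorophenyl group and the rest of the core of compound 1 kept as they are. Among the compounds shown here, they also leave open whether ethoxycarbonyl would give a similarly small step if a morpholine or a longer alkyl chain stood in place of the 4-chlorophenyl group, since only this one pair isolates the change.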